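The compounds below may be only part of what the source reports. "The series", "measured", "known", "first", "only" and "open" are said of these compounds alone.

Measured compounds:
- compound 1 `Fc1ccc(-c2cn3ccnc3c(-c3ccc4ncn(C5CCCCC5)c4c3)n2)cc1`: 18%
- compound 2 `c1cn2cc(-c3ccsc3)nc(-c3ccc4ncn(C5CCCCC5)c4c3)c2n1`: 13.4%
- compound 3 `Clc1ccc(-c2cn3ccnc3c(-c3ccc4ncn(C5CCCCC5)c4c3)n2)cc1`: 7.34%

In a functional assay on HCT-116 cells (Homo sapiens) for inhibition, read by sulforhodamine B assay, with a stated time of 48 h, tested at 10 uM (on this read-out higher numbers stand for more inhibition at the one concentration tested (going by the name of the read-out) and lower numbers for less inhibition), compound 3 stands beyond the scatter below compound 1, by a number 10.7 percentage points lower from compound 1 to compound 3 (beyond the scatter), while its gap to compound 2, a number 6.1 percentage points lower from compound 2 to compound 3 (within the scatter), lies within the scatter. Compound 4 `Brc1ccc(-c2cn3ccnc3c(-c3ccc4ncn(C5CCCCC5)c4c3)n2)cc1` differs from compound 3 by bromo in place of chloro on an aromatic carbon. For the measured compounds named here, only one measured step bears on this kind of change, the swap of one halogen for another from compound 1 to compound 3: a number 10.7 percentage points lower from compound 1 to compound 3 (beyond the scatter), modest but beyond the scatter. A second halogen swap of the same kind is therefore expected to move the number little, at most a small downward step, a number 2.3 percentage points lower from compound 3 to compound 4 (within the scatter), likely within the scatter. Compound 4 is expected to give about 5%, between 0% and 15%.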

Compound 4, a percentage reported as inhibition, at one concentration (the size of the read-out at that concentration, not a potency): 31.2%
Estimate against measurement, compound 4: 26.2 percentage points below; the whole stated range lies below it.
By their numbers in this assay, from the lowest: compounds 3, 2 and 1 (each within the scatter of the next, the first and the last beyond it); then compound 4.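

In this assay the halogen on this ring can raise the number as well as lower it: bromo in place of chloro gives a number 23.9 percentage points higher from compound 3 to compound 4 (beyond the scatter) and bromo in place of fluoro gives a number 13.2 percentage points higher from compound 1 to compound 4 (beyond the scatter), so going from fluoro through chloro to bromo, the number does not move in one direction. The phenyl ring bearing bromo also outdoes the thiophene, with a number 17.8 percentage points higher from compound 2 to compound 4 (beyond the scatter) making compound 4 the highest of the four. Nothing measured here explains this rise. Going by these compounds, whether iodo, a methoxy group or an amine at this position would go higher remains open. So does how compound 4 would behave at other concentrations, since one concentration gives no potency.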